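Propoxy to difluoromethoxy: an expected small rise

The compounds below may be only part of what the source reports. "The series", "measured", "known", "first", "only" and "open" are said of these compounds alone.

Among the compounds with values here, in an ADME assay on the whole organism (Mus musculus, strain CD-1) for pharmacokinetics, at a dose of 10 mg/kg by the oral route (on this read-out lower numbers stand for lower oral bioavailability and higher numbers for higher oral bioavailability), compound 1 (`CCCOc1cc([C@](O)(CCN(C)C)[C@@H](c2cc3cc(Br)ccc3nc2OC)c2ccnc(OC)c2OC)cc(OC)n1`) reaches 50% and holds the lower of the two numbers so far. Compound 2 (`COc1cc([C@](O)(CCN(C)C)[C@@H](c2cc3cc(C#N)ccc3nc2OC)c2cccc(C)c2F)cc(OC(F)F)n1`) stands higher at 66% and that gap lies beyond the scatter. Compound 3 (`COc1cc([C@](O)(CCN(C)C)[C@@H](c2cc3cc(Br)ccc3nc2OC)c2ccnc(OC)c2OC)cc(OC(F)F)n1`) has not been measured. It departs from compound 1 in one place (difluoromethyl in place of propyl on an oxygen on an aromatic ring): difluoromethyl in place of propyl on an oxygen on an aromatic ring. Compound 2 carries difluoromethyl too but differs elsewhere, so compound 2 at 66% is only a loose guide. Within the data shown here, no measured pair shows this change alone, so only a small rise within the scatter is expected in this assay (a number 5 percentage points higher from compound 1 to compound 3 (within the scatter)). For compound 3 the expected value is 55% within 38% to 72% on this estimate.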

Compound 3, oral bioavailability: 50%
For compound 3 the middle estimate is 5 percentage points above the measured one, and the stated range covers the measured number.
By their numbers in this assay, from the lowest: compounds 1 and 3 (each within the scatter of the next); then compound 2.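

Within the data shown here, for the first time, a pair of compounds isolates this one change on an oxygen on an aromatic ring, and in this assay the step reads no change at the digits printed from compound 1 to compound 3 (within the scatter). On this core, then, propyl and difluoromethyl at this place give oral bioavailability numbers that cannot be told apart. No available data offer an explanation for this result.

Still open, on these data alone, is how a longer chain such as butyl, or a trifluoromethyl group, would read at this oxygen. Also open, as far as these compounds go, is whether the same swap would read alike on a core with other groups, such as that of compound 2.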